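Styryl for phenyl on the pyrazoline core

The compounds below may be only part of what the source reports. "The series", "measured", "known", "first", "only" and "open" are said of these compounds alone.

Compound 1, `CC(=O)N1N=C(c2ccco2)CC1c1ccc(Cl)cc1`, gives 38900 nM in a functional assay on IMR-32 cells (Homo sapiens) for cytotoxicity, read by sulforhodamine B assay, with a stated time of 48 h; a lower number here means a stronger inhibitor, a higher number a weaker inhibitor.
Compound 2, `CC(=O)N1N=C(c2cccc3ccccc23)CC1c1ccco1`, gives 8000 nM in this assay.
Compound 3, `O=CCN1N=C(c2ccc3ccccc3c2)CC1c1ccccc1`, gives 10000 nM in this assay.

Among these three numbers compound 3 stands second highest. Its nearest neighbour is compound 2, whose value lies within the usual scatter of it, so no order between the two can be claimed. Its furthest neighbour is compound 1, whose number is higher by a margin beyond the scatter, so compound 1 is the weaker inhibitor of that pair.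

Compound 4, `O=CCN1N=C(c2ccc3ccccc3c2)CC1/C=C/c1ccccc1`, has not yet been measured. It differs from compound 3 in one place: 2-phenylethenyl in place of phenyl on a saturated ring carbon. Within the data shown here, no measured pair in this set shows the effect of such an exchange, so nothing here tells how large a step it should bring. In this assay the step from compound 3 to compound 4 is therefore expected to be small, not beyond the scatter, with no direction favoured, a 1.3-fold lower number from compound 3 to compound 4 (0.10 log units; within the scatter). Compound 4 is estimated at 8000 nM, within a range from 2500 nM to 30000 nM.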

Compound 4, half-maximal inhibitory concentration: 17200 nM
The estimate for compound 4 lay 2.2-fold (0.33 log units) below the measured number; low and high end bracket the measured number.
By their numbers in this assay, from the lowest: compounds 2, 3 and 4 (each within the scatter of the next, the first and the last beyond it); then compound 1.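

Among these compounds, the exchange gives the first reading of this position in this assay: a 1.7-fold higher number from compound 3 to compound 4 (0.24 log units; within the scatter). With the formylmethyl group and the rest of the core held fixed, the saturated ring carbon next to the ring nitrogen thus carries the larger 2-phenylethenyl group, with its double bond outside the aromatic ring, without a step beyond the scatter. Nothing available bears on why this step stays so small.

As far as these compounds go, whether a 2-phenylethyl group, which lacks that double bond, or an amine or a carboxylic acid on this carbon would bring a step beyond the scatter remains open. Also open, from the compounds shown here alone, is whether the same exchange would behave alike with an acetyl group, as in compound 1 and compound 2, in place of the formylmethyl group.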